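The compounds below may be only part of what the source reports. "The series", "measured", "known", "first", "only" and "open" are said of these compounds alone.

Measured compounds:
compound 1, `CCCC(Oc1ccc(-n2cc(C(F)(F)F)cn2)c(C)c1)c1ccc(C(=O)NCCC(=O)O)cc1`, 1900 nM
compound 2, `CCC(Oc1ccc(-n2cc(C(F)(F)F)cn2)cc1)c1ccc(C(=O)NCCC(=O)O)cc1`, > 22000 nM

In a functional assay on cells for antagonist activity at Glucagon receptor (Homo sapiens), read by cAMP accumulation, in the presence of a further agent that is not named here (a higher number here means a weaker inhibitor, a lower number a stronger inhibitor), compound 2 gives only a limit, > 22000 nM, which is the limit of > 22000 nM in this assay, at which 1 of the 2 values shown sits; compound 2 is the one of the two measured compounds without a number of its own. Compound 3, `O=C(O)CCNC(=O)c1ccc(C(Oc2ccc(-n3cc(C(F)(F)F)cn3)cc2)C2CCCC2)cc1`, differs from compound 2 by cyclopentyl in place of ethyl on a saturated chain carbon bound to an aromatic carbon and an oxygen on an aromatic ring. For the measured compounds named here, no single-point step between measured compounds is available, so the expected step is taken from the spread between compound 1 and compound 2. For compound 3 a large step toward stronger inhibition in this assay is expected, an at least 27-fold lower number from compound 2 to compound 3 (1.43 log units; beyond the scatter). Compound 3 is estimated at 800 nM, within a range from 150 nM to 5000 nM.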

Compound 3, antagonist equilibrium constant: 4000 nM
Compound 3: middle estimate off by 5.0-fold (0.70 log units), on the low side; measured number inside the range.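

In this assay, cyclopentyl in place of ethyl on a saturated chain carbon bound to an aromatic carbon and an oxygen on an aromatic ring gives an at least 5.5-fold lower number from compound 2 to compound 3 (0.74 log units; beyond the scatter). This shows that the group at this position alone moves the number, which compound 1 and compound 2, differing in more than one place, could not show. The true size of the step stays unknown, since compound 2 stands only at a limit: the limit of > 22000 nM in this assay, at which 1 of the 3 values shown sits.

The compounds shown leave open whether the ring itself or merely the added carbons carry the step, which an open-chain pentyl group would help to separate. They also leave open whether a cyclohexyl group would go further than cyclopentyl.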